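Perfluoroalkyl triazole chain extension in the benzothiazole-phenoxy series

The source may report more compounds than this note shows. Statements on the series, on what has been measured and on what is new or still open speak of the compounds shown alone.

Measured compounds:
compound 1 `FC(F)(F)C(F)(F)C(F)(F)C(F)(F)C(F)(F)C(F)(F)CCn1cc(COc2ccccc2-c2nc3ccccc3s2)nn1`, 35100 nM
compound 2 `Brc1ccc(-c2cc(COc3ccccc3-c3nc4ccccc4s3)on2)cc1`, 29200 nM
compound 3 `COc1ccc(-c2cc(COc3ccccc3-c3nc4ccccc4s3)on2)cc1`, 34100 nM

All three share the core of compound 1 and were run in an ADME assay on MCF-10A cells (Homo sapiens) for cytotoxicity, read by MTT assay, with a stated time of 24 h; on this read-out lower numbers stand for stronger inhibition and higher numbers for weaker inhibition. Compound 1 gives 35100 nM; compound 3 gives 34100 nM and compound 2 gives 29200 nM, both within the scatter of compound 1, so the three numbers cannot be told apart. Among the measured compounds shown here, the single measured step is a 1.2-fold higher number from compound 2 to compound 3 (0.07 log units; within the scatter), which concerns the two isoxazole-bearing compounds and a change on an aromatic carbon; it does not touch the chain on the triazole and so does not bear on the change at hand.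

Compound 4 `FC(F)(F)C(F)(F)C(F)(F)C(F)(F)C(F)(F)C(F)(F)C(F)(F)C(F)(F)CCn1cc(COc2ccccc2-c2nc3ccccc3s2)nn1` is not yet measured. It differs from compound 1 by 1,1,2,2,2-pentafluoroethyl in place of fluoro on a saturated chain carbon bound to two fluorine atoms and a saturated chain carbon. For the measured compounds named here, no measured pair in the set varies the length of this chain, so there is nothing to anchor a direction; the three measured numbers sit together, and the expectation is a step within the scatter. Compound 4 is expected to give 38000 nM in this assay, with a range from 18000 nM to 80000 nM, which corresponds to an expected 1.1-fold higher number from compound 1 to compound 4 (0.03 log units; within the scatter).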

Compound 4, half-maximal inhibitory concentration: 33100 nM
For compound 4 the middle estimate is 1.1-fold (0.06 log units) above the measured one; the measured number falls inside the stated range.
By their numbers in this assay, from the lowest: compounds 2, 4, 3 and 1 (each within the scatter of the next).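

In this assay, among the compounds shown here, the one change of chain length gives a 1.1-fold lower number from compound 1 to compound 4 (0.03 log units; within the scatter), so 1,1,2,2,2-pentafluoroethyl in place of fluoro on a saturated chain carbon bound to two fluorine atoms and a saturated chain carbon leaves the read-out within the scatter. The earlier compounds shown here varied only an aromatic carbon on the isoxazole-bearing compounds, whereas this pair shows that the fluorinated chain on the triazole can take this extension with no readable shift in this cytotoxicity read-out. No supporting data bear on why the number stays put.

As far as these compounds go, whether a non-fluorinated alkyl chain, an amine or a carboxylic acid in place of the fluorinated chain would shift the number remains open. So does whether any shorter fluorinated chain would depart from compound 1 and compound 4.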